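Chloro loss between ring nitrogens in a fused series

The compounds below may be only part of what the source reports. "The series", "measured", "known", "first", "only" and "open" are said of these compounds alone.

Measured compounds:
compound 1 `ClCc1ccc(Cn2cnc3c(Cl)ncnc32)cc1`: 4780 nM
compound 2 `ClCc1ccccc1Cn1cnc2c(Cl)nc(Cl)nc21`: 200 nM

In a functional assay on MOLT-4 cells (Homo sapiens) for cytotoxicity, read by sulforhodamine B assay, with a stated time of 48 h (on this read-out higher numbers stand for weaker inhibition of growth and lower numbers for stronger inhibition of growth), compound 2 gives 200 nM, the lowest of the two numbers. Compound 1 gives 4780 nM in this assay, a number far higher than that of compound 2; the two compounds differ in more than one place, so the values alone are all that can be said of them.

Compound 3 `ClCc1ccccc1Cn1cnc2c(Cl)ncnc21` is not yet measured in this assay. It differs from compound 2 in one place: hydrogen in place of chloro on an aromatic carbon. Within the data shown here, the two measured compounds give no single-change step against which this change can be set. Compound 1, which also lacks a chloro at that place, gives 4780 nM, so weaker inhibition of growth than compound 2 is expected, by an estimated 7.5-fold higher number from compound 2 to compound 3 (0.88 log units; beyond the scatter). Compound 3 is expected to give about 1500 nM, within 400 nM to 6000 nM.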

Compound 3, concentration for 50% growth inhibition: 1580 nM
For compound 3 the middle estimate is 1.1-fold (0.02 log units) below the measured one; the measured number falls inside the stated range.
By their numbers in this assay, from the lowest: compound 2; then compound 3; then compound 1.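

In this assay, the chloro on the aromatic carbon between two ring nitrogen atoms can now be read as a single change: hydrogen in its place gives a weaker inhibition of growth (a 7.9-fold higher number from compound 2 to compound 3 (0.90 log units; beyond the scatter)). The earlier pair differed in more than one place and could not separate this chloro from the other changes. For this pair, the chloro at this place therefore goes with the stronger inhibition of growth, on a step beyond the scatter, and nothing at hand bears on the reason for the step.

On these data alone, whether the chloro is specifically favoured remains open, as only hydrogen has been set against it here; an amine, a methoxy or a fluoro at this place could show how much depends on the group. Also open, as far as these compounds go, is how the chloro group that remains on the same ring and the chloromethyl group each bear on the read-out.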